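This account rests on a few compounds, and the source may have more. Where it says the series, first, only, none or still open, it means among the compounds named here.

Working notes on an adenine nucleotide triphosphate series carrying an iodoacetamide chain.

Compound 1 `Nc1ncnc2c1nc(NCCCCNC(=O)CI)n2[C@@H]1O[C@H](COP(=O)(O)OP(=O)(O)OP(=O)(O)O)[C@@H](O)[C@H]1O` is the reference. In an assay on isolated protein for inhibition of hexokinase-1 (Rattus norvegicus), with a stated time of 6 h, tested at 10 mM (on this read-out higher numbers stand for more inhibition at the one concentration tested (going by the name of the read-out) and lower numbers for less inhibition), compound 1 gives 0%. Compound 3 `Nc1ncnc2c1nc(NCCCCCCNC(=O)CI)n2[C@@H]1O[C@H](COP(=O)(O)OP(=O)(O)OP(=O)(O)O)[C@@H](O)[C@H]1O` carries the same core with a longer chain: the change from compound 1 to compound 3 is 2-(((iodomethyl)carbonyl)amino)ethyl in place of ((iodomethyl)carbonyl)amino on a saturated chain carbon, four bonds along the chain from a nitrogen on an aromatic ring. In this assay compound 3 gives 0%, and the step of no change at the digits printed from compound 1 to compound 3 (within the scatter) lies within the scatter, so lengthening the chain at that place does not register here.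

Compound 2 `CN(CCCCN(C)c1ncnc2c1ncn2[C@@H]1O[C@H](COP(=O)(O)OP(=O)(O)OP(=O)(O)O)[C@@H](O)[C@H]1O)C(=O)CCCNC(=O)CI` differs from compound 1 in more than one place; the difference between the two cores is not broken down here. In this assay compound 2 gives 0%, level with compounds 1 and 3 at the digits printed.

Compound 4 `CN(CCCCN(C)c1ncnc2c1ncn2[C@@H]1O[C@H](COP(=O)(O)OP(=O)(O)OP(=O)(O)O)[C@@H](O)[C@H]1O)C(=O)CCCCCNC(=O)CI` is not yet measured. The change from compound 2 to compound 4 is 2-(((iodomethyl)carbonyl)amino)ethyl in place of ((iodomethyl)carbonyl)amino on a saturated chain carbon, three bonds along the chain from a carbonyl carbon. Going by the values given here, it is the same kind of change as the one from compound 1 to compound 3, but the place is not the same: in compound 1 the chain grows four bonds along the chain from a nitrogen on an aromatic ring, whereas in compound 2 it grows three bonds along the chain from a carbonyl carbon.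

Since the earlier step of no change at the digits printed from compound 1 to compound 3 (within the scatter) showed no change and compound 2 already gives 0%, the step from compound 2 to compound 4 is expected to be no change at the digits printed from compound 2 to compound 4 (within the scatter). The estimate for compound 4 in this assay is 0%, expected to fall between 0% and 10%.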

Compound 4, a percentage reported as inhibition, at one concentration (the size of the read-out at that concentration, not a potency): 0%
For compound 4 middle estimate and measured number coincide at the digits printed; low and high end bracket the measured number.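

In this assay, the new step reads no change at the digits printed from compound 2 to compound 4 (within the scatter), so adding two chain carbons on the side chain of compound 2 does not register. Set beside the earlier step on the core of compound 1, the same change reads alike on the two cores, although its place differs: the same change on two cores in this assay, no change at the digits printed (within the scatter) from compound 1 to compound 3 and no change at the digits printed (within the scatter) from compound 2 to compound 4, 0 percentage points apart, within the scatter of two such steps This agreement is only an agreement between two null steps at the one concentration tested: all four compounds print the same value, so there is no measured effect of the change to carry from one core to the other, and the pair does not show how the change would behave on a compound that registers inhibition in this read-out.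

The compounds shown leave open whether any member of the series registers in this assay, and whether a longer chain, or an amine or a carboxylic acid in place of the ((iodomethyl)carbonyl)amino end, would move the read-out on either core. They also leave open how the difference between the two cores acts on its own, as compounds 1 and 2 differ in more than one place and that difference cannot be read as a single step.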